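Phenoxypentyl uracils: bromo for propoxycarbonyl, tolerated concentration

The source may report more compounds than this note shows. Statements on the series, on what has been measured and on what is new or still open speak of the compounds shown alone.

Compound 1 `O=c1ccn(CCCCCOc2ccccc2)c(=O)[nH]1` carries the shared core on a five-carbon chain to a phenoxy group. In an ADME assay on HEL cells (Homo sapiens) for cytotoxicity (a lower number here means that less compound is tolerated, a higher number that more compound is tolerated), compound 1 gives only a limit, > 100000 nM. Compound 2 `O=c1ccn(CCCCCOc2ccc(-c3ccccc3)cc2)c(=O)[nH]1` extends the phenoxy group by a second phenyl ring; in this assay compound 2 gives "not determined" (no result reported), so no number exists for it. Compound 3 `CCCOC(=O)c1ccc(OCCCCCn2ccc(=O)[nH]c2=O)cc1` bears a propoxycarbonyl on an aromatic carbon of the phenoxy ring. In this assay compound 3 likewise gives only a limit, > 100000 nM. Compound 3 therefore stands where every measured compound of the series stands, at the limit of > 100000 nM in this assay, at which 2 of the 3 values shown sit. For the measured compounds named here, the one measured step, a step that the two limits leave unreadable from compound 1 to compound 3, cannot be read because a step that the two limits leave unreadable from compound 1 to compound 3 has a limit at both ends.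

Compound 4 `O=c1ccn(CCCCCOc2ccc(Br)cc2)c(=O)[nH]1` differs from compound 3 by bromo in place of propoxycarbonyl on an aromatic carbon. Going by the values given here, no measured step involves a bromo group, and the only measured step gives neither size nor direction, so the expectation rests on the fact that both measured values sit at the limit. Compound 4 is expected to give about 150000 nM in this assay, within a range from 50000 nM to 500000 nM, and most probably to be reported as a limit again. The expected step that the limit leaves unreadable from compound 3 to compound 4 is none beyond the scatter.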

Compound 4, half-maximal cytotoxic concentration: > 100000 nM
Compound 4: a limit, no number; the forecaster's own chance of this, stated with the estimate: 80%; the middle value lies beyond the limit too.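

In this assay compound 4 gives > 100000 nM, again a limit and not a number, so the steps to compound 4 from compound 1 and from compound 3 cannot be read. The compounds shown leave open at what concentration compound 1, compound 3 or compound 4 would reach the half-maximal cytotoxic read-out, and whether hydrogen, propoxycarbonyl and bromo differ at all.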